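A few compounds are considered here, and "the series" means these few. Any claim that something is new, unique, unknown or untested is made for them only; others in the source may bear on it.

Working notes on the series, read in a functional assay on MDA-MB-231 cells (Homo sapiens) for antiproliferative activity, read by MTT assay, with a stated time of 72 h; on this read-out higher numbers stand for weaker inhibition and lower numbers for stronger inhibition. Compound 1 (`COc1cc(/C=C/C(=O)/C=C(O)/C=C/c2ccc(OC(=O)C(C)(CO)CO)c(OC)c2)ccc1OC(=O)C(C)(CO)CO`) gives 2670 nM and compound 2 (`CCC(CO)(CO)C(=O)Oc1ccc(/C=C/C(=O)/C=C(O)/C=C/c2ccc(OC(=O)C(CC)(CO)CO)c(OC)c2)cc1OC`) gives 2000 nM, two values within the scatter of each other. Compound 3 (`COc1cc(/C=C/C(O)=C/C(=O)/C=C/c2ccc(OC(=O)C(C)(CO)CO)c(OC)c2)ccc1O`) gives 5940 nM, the highest number of the three and beyond the scatter from both of the others.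

Compound 4 (`CCC(CO)(CO)C(=O)Oc1ccc(/C=C/C(=O)/C=C(O)/C=C/c2ccc(O)c(OC)c2)cc1OC`) follows from compound 3 by one change: methyl in place of hydrogen on a saturated chain carbon, two bonds along the chain from a carbonyl carbon. It sits on a saturated chain carbon, two bonds along the chain from a carbonyl carbon, and cut one bond further out it reads (1,1-bis(hydroxymethyl)ethyl)carbonyl to (1,1-bis(hydroxymethyl)propyl)carbonyl.

Among the compounds with values here, the only measured step, a 2.2-fold higher number from compound 1 to compound 3 (0.35 log units; beyond the scatter), is modest and concerns the loss of a whole (1,1-bis(hydroxymethyl)ethyl)carbonyl group, so it does not size this change. The closer evidence is the pair of compound 1 and compound 2, which carry the ethyl and propyl forms of this group, and their values stay within the scatter. Within the data shown here, no measured pair shows this exchange alone on a compound with a single such group.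

No step beyond the scatter is therefore expected in this assay, and the expected step is a 1.2-fold lower number from compound 3 to compound 4 (0.09 log units; within the scatter). The estimate for compound 4 is 4800 nM, with an expected range from 2700 nM to 8000 nM.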

Compound 4, half-maximal inhibitory concentration: 4660 nM
The estimate for compound 4 lay 1.0-fold (0.01 log units) above the measured number; the range from low to high includes it.
By their numbers in this assay, from the lowest: compounds 2, 1, 4 and 3 (each within the scatter of the next, the first and the last beyond it).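

In this assay, methyl in place of hydrogen on a saturated chain carbon, two bonds along the chain from a carbonyl carbon, can now be read alone on a compound with a single (1,1-bis(hydroxymethyl)propyl)carbonyl group, and the exchange stays within the scatter (a 1.3-fold lower number from compound 3 to compound 4 (0.11 log units; within the scatter)). Removing the whole group from an oxygen on an aromatic ring, previously seen only for the (1,1-bis(hydroxymethyl)ethyl)carbonyl form (a 2.2-fold higher number from compound 1 to compound 3 (0.35 log units; beyond the scatter)), now has a counterpart in the (1,1-bis(hydroxymethyl)propyl)carbonyl form (a 2.3-fold higher number from compound 2 to compound 4 (0.37 log units; beyond the scatter)), and both steps are modest but beyond the scatter. No available evidence accounts for either result.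

The compounds shown leave open whether a longer chain, such as propyl or butyl in place of the ethyl now on this saturated chain carbon, would stay within the scatter. They also leave open whether an amine or a carboxylic acid in place of hydroxymethyl would change the number in this assay beyond the scatter.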